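Swapping Hydroxy for Dimethylamino in an Antiproliferative Series

The source may report more compounds than this note shows. Statements on the series, on what has been measured and on what is new or still open speak of the compounds shown alone.

In a functional assay on HCT-8 cells (Homo sapiens) for antiproliferative activity, read by MTT assay, with a stated time of 48 h (a higher number here means a weaker inhibitor, a lower number a stronger inhibitor), compound 1 (`C=C(c1ccc2c(c1)C=CC(C)(C)O2)c1ccc(OC)cc1NC(=O)CO`) gives 220 nM and sits in the middle of three measured numbers: compound 2 (`C=C(c1cc(OC)c(OC)c(OC)c1)c1ccc(OC)cc1NC(=O)CO`) is lower at 40 nM and compound 3 (`C=C(c1ccc(OC)cc1NC(=O)CN)c1ccc(OC)c2c1C=CC(C)(C)O2`) is higher at 520 nM in this small set. Among the compounds with values here, compound 4 (`C=C(c1ccc2c(c1)C=CC(C)(C)O2)c1ccc(OC)cc1NC(=O)CN(C)C`) keeps the core of compound 1, and dimethylamino in place of hydroxy on a saturated chain carbon bound to a carbonyl carbon describes its one change: dimethylamino in place of hydroxy on a saturated chain carbon bound to a carbonyl carbon. Within the data shown here, no measured pair isolates this swap. With nitrogen on that chain carbon but a different core, compound 3 gives 520 nM as only a loose guide. The step expected is a 1.8-fold higher number from compound 1 to compound 4 (0.26 log units; within the scatter) in this assay and no larger than the usual scatter. For compound 4 the estimate is 400 nM with an expected range from 130 nM to 1200 nM until it is tested.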

Compound 4, half-maximal inhibitory concentration: 690 nM
Beside the measured number, compound 4's estimate is 1.7-fold (0.24 log units) below it; the measured number falls inside the stated range.
By their numbers in this assay, from the lowest: compound 2; then compound 1; then compounds 3 and 4 (each within the scatter of the next).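

On the shared core, putting dimethylamino in place of hydroxy on a saturated chain carbon bound to a carbonyl carbon gives a 3.1-fold higher number from compound 1 to compound 4 (0.50 log units; beyond the scatter) in this assay. Within the data shown here, this is the first direct reading of the swap, and it shows that this position responds to the change, though only modestly. The swap removes a hydrogen-bond donor and adds heavy atoms, and nothing measured here separates these differences or explains the step.

On these data alone, whether a plain amine or methylamino would behave more like hydroxy or more like dimethylamino remains open. So does whether a longer chain ending in dimethylamino, or the same swap on the core of compound 2, would give a step of similar size.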